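Fluoro at the para position of the terminal anilide

The source may hold more compounds than are shown below. What is called first, only, known or untested is meant among the compounds shown, and "the series" means these compounds.

Compound 1, `CN(C)C(=O)c1cc2cnc(Nc3ccc(NC(=O)C4(C(=O)Nc5ccccc5)CC4)cc3)nc2n1C1CCCC1`, carries an unsubstituted phenyl on the outer amide nitrogen of the cyclopropane diamide. For the measured compounds named here, in a functional assay on OVCAR-5 cells (Homo sapiens) for inhibition, read by CCK-8 assay, with a stated time of 72 h, tested at 1 uM (a lower number here means less inhibition of growth, a higher number more inhibition of growth at the concentration tested), compound 1 gives 52.1%, the highest of the three numbers measured so far. Compound 2, `CN(C)C(=O)c1cc2cnc(Nc3ccc(NC(=O)C4(C(=O)Nc5cccc(Cl)c5)CC4)cc3)nc2n1C1CCCC1`, gives 15.5% in this assay, and compound 3, `CN(C)C(=O)c1cc2cnc(Nc3ccc(NC(=O)C4(C(=O)Nc5ccc(Cl)cc5)CC4)cc3)nc2n1C1CCCC1`, gives 8.1%. The two steps from the parent are both large: a number 36.6 percentage points lower from compound 1 to compound 2 (beyond the scatter) and a number 44 percentage points lower from compound 1 to compound 3 (beyond the scatter). Between the two chloro isomers the gap is small, a number 7.4 percentage points lower from compound 2 to compound 3 (within the scatter).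

Compound 4, `CN(C)C(=O)c1cc2cnc(Nc3ccc(NC(=O)C4(C(=O)Nc5ccc(F)cc5)CC4)cc3)nc2n1C1CCCC1`, is the next step from compound 1: fluoro in place of hydrogen on an aromatic carbon. The change sits at the same aromatic carbon that carries chloro in compound 3, so the steps from compound 1 to compound 2 and to compound 3 are the ones that bear on it, and both point to a clear loss of growth inhibition in this assay. Fluoro is a smaller substituent than chloro, and no fluoro analogue has been measured, so the size of the drop is uncertain; a decrease beyond the scatter is expected, a number 28.1 percentage points lower from compound 1 to compound 4 (beyond the scatter), but possibly less steep than for the chloro compounds. For compound 4 the expected value in this assay is 24%, estimated to lie between 6% and 48%.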

Compound 4, percent growth inhibition at one concentration: 65.4%
Estimate against measurement, compound 4: 41.4 percentage points below, outside the stated range (above it).
By their numbers in this assay, from the lowest: compounds 3 and 2 (each within the scatter of the next); then compound 1; then compound 4.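

At this aromatic carbon the halogen decides the direction: fluoro in place of hydrogen gives a number 13.3 percentage points higher from compound 1 to compound 4 (beyond the scatter) in this assay while chloro at the same carbon, in compound 3, lowers the number, so a halogen here does not in itself cost growth inhibition. Exchanging chloro for fluoro on that carbon gives a number 57.3 percentage points higher from compound 3 to compound 4 (beyond the scatter) and moving from the 3-chlorophenyl amide to the 4-fluorophenyl amide gives a number 49.9 percentage points higher from compound 2 to compound 4 (beyond the scatter) so compound 4 stands apart from both chloro compounds. Nothing shown accounts for the gap between fluoro and chloro at this carbon.

Still open, as far as these compounds go, is whether a methoxy group, an amine or a nitrile on this carbon would keep the gain, and how 3-fluorophenyl compares. Also open, from the compounds shown here alone, is whether compound 4 stays ahead of compound 1 at other concentrations or in other cell lines.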